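The compounds below may be only part of what the source reports. "The series", "measured", "known", "first", "only" and "open" are said of these compounds alone.

In an assay on HEK293 cells for inhibition of lipoprotein lipase (Homo sapiens), with a stated time of 10 min (on this read-out lower numbers stand for stronger inhibition and higher numbers for weaker inhibition), three measured compounds set the scene. Compound 1 `CCCc1ccc(B2OC(C)(C)C(C)(C)O2)cc1` gives 25000 nM, compound 2 `CCCCCCCCCc1ccc(B2OC(C)(C)C(C)(C)O2)cc1` gives 15000 nM, and compound 3 `CC1(C)OB(c2ccc(-c3ccccc3)cc2)OC1(C)C` gives 12000 nM. Compound 3 thus carries the lowest number of the three, although its gap to compound 2 lies within the scatter; only against compound 1 is the gap clear, as the step of a 2.1-fold lower number from compound 1 to compound 3 (0.32 log units; beyond the scatter) shows. The other measured step, hexyl in place of hydrogen, a 1.7-fold lower number from compound 1 to compound 2 (0.22 log units; within the scatter), stayed within the scatter.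

Compound 4 `CC1(C)OB(c2ccc(-c3ccsc3)cc2)OC1(C)C` differs from compound 3 by thiophen-3-yl in place of phenyl on an aromatic carbon. For the measured compounds named here, no measured step exchanges one aromatic ring for another; the closest guide is the modest change in a 2.1-fold lower number from compound 1 to compound 3 (0.32 log units; beyond the scatter), which introduced the phenyl but says nothing about replacing it with thiophen-3-yl. With no direct evidence in this assay, the expected step is none beyond the scatter, no change at the digits printed from compound 3 to compound 4 (within the scatter). Compound 4 is therefore estimated at 12000 nM, with a range from 5000 nM to 30000 nM.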

Compound 4, half-maximal inhibitory concentration: 36000 nM
Compound 4: the middle estimate sits 3.0-fold (0.48 log units) below what was measured; the measured number lies above the stated range.
By their numbers in this assay, from the lowest: compounds 3, 2, 1 and 4 (each within the scatter of the next, the first and the last beyond it).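

In this assay, exchanging one aromatic ring for another at this position is not neutral: thiophen-3-yl in place of phenyl gives a 3.0-fold higher number from compound 3 to compound 4 (0.48 log units; beyond the scatter), a shift toward weaker inhibition. Set against the propyl group, the same ring gives a 1.4-fold higher number from compound 1 to compound 4 (0.16 log units; within the scatter), so an aromatic ring on this carbon does not by itself bring the clear gain over compound 1 that compound 3 shows. No measurement at hand explains why the two rings differ.

Ring size and the sulfur atom change together in this swap, so the compounds shown cannot tell which of them goes with the higher number. Going by these compounds, a furan-3-yl ring or a pyridin-3-yl ring at the same place could help separate the two, and how an amine or a carboxylic acid on the phenyl ring would behave also stays open.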